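The source may hold more compounds than are shown below. What is called first, only, known or untested is meant among the compounds shown, and "the series" means these compounds.

The two measured compounds share one core: compound 1 `CN(Cc1ccccc1)C1CCN(CCCc2c[nH]c3ccc(-n4cnnc4)cc23)CC1` and compound 2 `FC1(CCc2ccccc2)CCN(CCCc2c[nH]c3ccc(-n4cnnc4)cc23)CC1`. In an assay on CHO cells for displacement of a labelled ligand from 5-hydroxytryptamine receptor 1D (Homo sapiens) (a higher number here means a weaker inhibitor, a lower number a stronger inhibitor), compound 1 gives 2.1 nM, and in the same assay compound 2 gives 2 nM. Compound 2 thus holds the lower of the two numbers, but its gap to compound 1 lies within the scatter, so the two cannot be told apart. Compound 3 `Fc1ccc(CCC2(F)CCN(CCCc3c[nH]c4ccc(-n5cnnc5)cc34)CC2)cc1` differs from compound 2 in one place: fluoro in place of hydrogen on an aromatic carbon. Among the compounds with values here, no measured pair here shows what such a change does, so there is nothing to lean on beyond the closeness of compound 1 and compound 2. One fluorine in place of a hydrogen on that aromatic carbon is expected to leave this assay roughly where it stands, with no step beyond the scatter in either direction. Compound 3 is therefore estimated at 2.2 nM, within a range of 0.8 nM to 6 nM. The expected step reads a 1.1-fold higher number from compound 2 to compound 3 (0.04 log units; within the scatter).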

Compound 3, half-maximal inhibitory concentration: 1 nM
Estimate against measurement, compound 3: 2.2-fold (0.34 log units) above; low and high end bracket the measured number.
By their numbers in this assay, from the lowest: compounds 3, 2 and 1 (each within the scatter of the next, the first and the last beyond it).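

Phenyl to 2-(4-fluorophenyl) is the wrong name for this change, so it is best read as phenethyl to 2-(4-fluorophenyl)ethyl: compound 3 carries this change, and it gives the first measured comparison of compounds differing in one place. In this assay the step stays within the scatter (a 2.0-fold lower number from compound 2 to compound 3 (0.30 log units; within the scatter)), so compound 2 and compound 3 cannot be told apart. An aromatic carbon para to a large group can thus carry fluoro in place of hydrogen with no step beyond the scatter in this pair. Nothing at hand bears on why the two compounds read as they do.

The compounds shown leave open whether a chloro, methoxy or trifluoromethyl group at this carbon would read the same way. They also leave open what a fluoro at another carbon of this ring would do.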